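Swapping the Urea Aryl Group: Compound 3 to Compound 4

This account rests on a few compounds, and the source may have more. Where it says the series, first, only, none or still open, it means among the compounds named here.

Compound 1 `Cc1cc(C)cc(NC(=O)NCCNS(=O)(=O)c2ccc(-c3ccccc3OCc3ccccc3)s2)c1` gives > 50000 nM in a functional assay on RS4-11 cells (Homo sapiens) for inhibition, read by CCK-8 assay, with a stated time of 48 h (a lower number here means a stronger inhibitor, a higher number a weaker inhibitor), which is a limit of the assay and not a number.
Compound 2 `O=C(NCCNS(=O)(=O)c1ccc(-c2ccccc2O[C@H]2CC[C@@H](O)CC2)s1)Nc1ccc([N+](=O)[O-])cc1` gives 12400 nM in this assay.
Compound 3 `Cc1cc(C)cc(NC(=O)NCCNS(=O)(=O)c2ccc(-c3ccccc3Oc3ccc([N+](=O)[O-])c([N+](=O)[O-])c3)s2)c1` gives 3600 nM in this assay.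

Of the two numbers shown, compound 3 stands lowest; its nearest neighbour, compound 2, gives the higher number. For the measured compounds named here, the only measured step, an at least 13-fold lower number from compound 1 to compound 3 (1.14 log units; beyond the scatter), altered another part of the molecule and offers no direct guide here. Compound 4 `O=C(NCCNS(=O)(=O)c1ccc(-c2ccccc2Oc2ccc([N+](=O)[O-])c([N+](=O)[O-])c2)s1)Nc1ccc([N+](=O)[O-])cc1` differs from compound 3 in one place: 4-nitrophenyl in place of 3,5-dimethylphenyl on an amide-type nitrogen. Going by the values given here, compound 2 also carries the 4-nitrophenyl group on the amide-type nitrogen, yet it differs from compound 3 elsewhere too, so no single step links it to either compound. Without a direct precedent, the expected change is a 1.3-fold higher number from compound 3 to compound 4 (0.10 log units; within the scatter), not beyond the scatter. Compound 4 is therefore estimated at 4500 nM, within 1300 nM to 16000 nM.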

Compound 4, half-maximal inhibitory concentration: 3000 nM
For compound 4 the middle estimate is 1.5-fold (0.18 log units) above the measured one; measured number inside the range.
By their numbers in this assay, from the lowest: compounds 4 and 3 (each within the scatter of the next); then compound 2. At a limit, above all of these: compound 1.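

On the amide-type nitrogen, 4-nitrophenyl in place of 3,5-dimethylphenyl gives a 1.2-fold lower number from compound 3 to compound 4 (0.08 log units; within the scatter) in this assay, so these two groups cannot be told apart at this position. With 4-nitrophenyl on that nitrogen in both compounds, 3,4-dinitrophenyl in place of 4-hydroxycyclohexyl on the oxygen gives a 4.1-fold lower number from compound 2 to compound 4 (0.62 log units; beyond the scatter), a step with a measured number at both ends. Nothing measured here accounts for either step.

The compounds shown leave open how a 4-aminophenyl group, a 4-carboxyphenyl group or a longer alkyl chain would read on that nitrogen. They also leave open whether a 4-nitrophenyl group on the oxygen would match 3,4-dinitrophenyl.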